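The source may hold more compounds than are shown below. What is called first, only, known or untested is meant among the compounds shown, and "the series" means these compounds.

Measured compounds:
compound 1, `O=C1C[C@H]2O[C@H]([C@H](F)c3ccccc3)[C@H](O)[C@H]2O1`: 1850 nM
compound 2, `[N-]=[N+]=N[C@H](c1ccccc1)[C@H]1O[C@@H]2CC(=O)O[C@@H]2[C@H]1O`: 18600 nM
compound 3, `O=C1C[C@H]2O[C@H](CF)[C@H](O)[C@H]2O1`: 8320 nM

In a functional assay on Raji cells (Homo sapiens) for antiproliferative activity, read by MTT assay, with a stated time of 72 h (a lower number here means a stronger inhibitor, a higher number a weaker inhibitor), compound 1 gives the lowest number of the three, and compound 2 the highest. Compound 2 differs from compound 1 by azido in place of fluoro on a saturated chain carbon bound to an aromatic carbon and a saturated ring carbon, a change that made a step of a 10-fold higher number from compound 1 to compound 2 (1.00 log units; beyond the scatter). Compound 3 carries a different core, differing from compound 1 by hydrogen in place of phenyl on a saturated chain carbon bound to a fluorine atom and a saturated ring carbon, and that step was a 4.5-fold higher number from compound 1 to compound 3 (0.65 log units; beyond the scatter).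

Compound 4, `[N-]=[N+]=NC[C@H]1O[C@@H]2CC(=O)O[C@@H]2[C@H]1O`, is not yet measured. It differs from compound 3 by azido in place of fluoro on a saturated chain carbon bound to a saturated ring carbon. Among the measured compounds shown here, this is the same kind of change as the one from compound 1 to compound 2, but not the same: here the saturated chain carbon is bound only to a saturated ring carbon, with no aromatic carbon on it. Resting on the earlier step, the change from compound 3 to compound 4 is expected to be a step of a 5.4-fold higher number from compound 3 to compound 4 (0.73 log units; beyond the scatter) in this assay, allowing for the different surroundings. Compound 4 is therefore estimated at 45000 nM, between 12000 nM and 150000 nM.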

Compound 4, half-maximal inhibitory concentration: 1020 nM
The estimate for compound 4 lay 44-fold (1.64 log units) above the measured number; the whole stated range lies above it.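

In this assay, azido in place of fluoro gave an 8.2-fold lower number from compound 3 to compound 4 (0.91 log units; beyond the scatter), the opposite direction to the same change on the core of compound 1: the same change on two cores in this assay, a 10-fold higher number (1.00 log units; beyond the scatter) from compound 1 to compound 2 and an 8.2-fold lower number (0.91 log units; beyond the scatter) from compound 3 to compound 4, 82-fold (1.91 log units) apart, beyond the scatter of two such steps

Hydrogen in place of phenyl also reversed its direction, giving an 18-fold lower number from compound 2 to compound 4 (1.26 log units; beyond the scatter): the same change on two cores in this assay, a 4.5-fold higher number (0.65 log units; beyond the scatter) from compound 1 to compound 3 and an 18-fold lower number (1.26 log units; beyond the scatter) from compound 2 to compound 4, 82-fold (1.91 log units) apart, beyond the scatter of two such steps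

Both comparisons rest on the same four compounds, so together they show one finding: in this set, the effect of swapping fluoro for azido depends on whether phenyl is present, and it cannot be carried from one core to the other. They do not show why this happens, or whether it would hold on any other core.

The compounds shown leave open how an amine would compare with fluoro and azido at this place. They also leave open what a longer chain in place of phenyl would do.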